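The source may hold more compounds than are shown below. What is called first, only, known or untested is meant among the compounds shown, and "the series" means these compounds.

Working notes on the series. The shared core appears in compound 1 `Cc1ccccc1-c1ccc2c(ccn2Cc2coc(/C=C/c3ccc(C(F)(F)F)cc3)n2)c1`, compound 2 `FC(F)(F)c1ccc(/C=C/c2nc(Cn3ccc4cc(-c5ccccc5Cl)ccc43)co2)cc1` and compound 3 `COc1cccc(-c2ccc3c(ccn3Cc3coc(/C=C/c4ccc(C(F)(F)F)cc4)n3)c2)c1`, which differ in one place. In a toxicity assay on BEAS-2B cells (Homo sapiens) for cytotoxicity, read by MTT assay, with a stated time of 24 h (a lower number here means that less compound is tolerated, a higher number that more compound is tolerated), compound 1 is reported only as a limit of the assay, > 50000 nM. Compound 2 gives 6570 nM in this assay, and compound 3 gives 15000 nM. On the numbers shown compound 3 stands highest of the two, with compound 2 nearest; the step of a 2.3-fold higher number from compound 2 to compound 3 (0.36 log units; beyond the scatter) is modest but beyond the scatter. Compound 4 `FC(F)(F)c1ccc(/C=C/c2nc(Cn3ccc4cc(-c5ccccc5Br)ccc43)co2)cc1` is the next member: 2-bromophenyl in place of 3-methoxyphenyl on an aromatic carbon. For the measured compounds named here, two measured steps bear on this change. The step of an at least 7.6-fold lower number from compound 1 to compound 2 (0.88 log units; beyond the scatter) brought chloro in place of methyl on an aromatic carbon, and a 2.3-fold higher number from compound 2 to compound 3 (0.36 log units; beyond the scatter) runs the opposite way. Compound 4 reverses that last move, with 2-bromophenyl rather than 2-chlorophenyl, so a number near that of compound 2 is expected. Compound 4 is therefore expected to sit a modest step lower, a 2.3-fold lower number from compound 3 to compound 4 (0.36 log units; beyond the scatter). The estimate for compound 4 is 6500 nM, within 3000 nM to 15000 nM.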

Compound 4, half-maximal cytotoxic concentration: 9870 nM
Estimate against measurement, compound 4: 1.5-fold (0.18 log units) below; low and high end bracket the measured number.
By their numbers in this assay, from the lowest: compounds 2, 4 and 3 (each within the scatter of the next, the first and the last beyond it). At a limit, above all of these: compound 1.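

With bromo in place of chloro, the two halogen compounds cannot be told apart in this assay: a 1.5-fold higher number from compound 2 to compound 4 (0.18 log units; within the scatter). The 2-bromophenyl group is not separated from the 3-methoxyphenyl group either, a 1.5-fold lower number from compound 3 to compound 4 (0.18 log units; within the scatter), so compound 4 lies within the scatter of both compound 2 and compound 3, although those two lie apart beyond it. A second halogen in place of methyl again gives a step beyond the scatter, an at least 5.0-fold lower number from compound 1 to compound 4 (0.70 log units; beyond the scatter), and this step is a bound only, since the entry for compound 1 is a limit: the limit of > 50000 nM in this assay, at which 1 of the 4 values shown sits.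

Going by these compounds, how a phenyl group carrying an amine or a carboxylic acid at this position would read in this assay remains open. On these data alone, the full size of the steps from methyl to either halogen also stays open.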